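This account rests on a few compounds, and the source may have more. Where it says the series, first, only, none or still open, it means among the compounds named here.

Measured so far:
Compound 1, `CC(C(=O)NCc1ccc(C(F)(F)F)cc1OC1CCCCC1)c1ccc(NS(C)(=O)=O)c(F)c1`, gives 0.7 nM in an assay on CHO cells for antagonist activity at transient receptor potential cation channel subfamily V member 1 (Homo sapiens), read by FLIPR; a lower number here means a stronger inhibitor, a higher number a weaker inhibitor.
Compound 2, `COc1ccc(CSc2cc(C(F)(F)F)ccc2CNC(=O)C(C)c2ccc(NS(C)(=O)=O)c(F)c2)cc1`, gives 2.3 nM in this assay.

Going by the values given here, compound 2 stands at the higher of these two numbers; its nearest neighbour is compound 1, and the single step between them, a 3.3-fold higher number from compound 1 to compound 2 (0.52 log units; beyond the scatter), is modest yet beyond the scatter. Compound 3, `CC(C(=O)NCc1ccc(C(F)(F)F)cc1SCc1ccco1)c1ccc(NS(C)(=O)=O)c(F)c1`, awaits measurement. It differs from compound 2 in one place: furan-2-yl in place of 4-methoxyphenyl on a saturated chain carbon bound to a sulfur. Among the compounds with values here, no measured step covers this exchange. Within the data shown here, the only step in hand, a 3.3-fold higher number from compound 1 to compound 2 (0.52 log units; beyond the scatter), concerns a different swap at the same place, cyclohexyloxy against (4-methoxybenzyl)sulfanyl, and shows that this part of the molecule can move the number modestly. With the sulfanyl link and the methylene kept and only the aromatic on the saturated chain carbon exchanged, compound 3 is expected to shift only a little, a 1.5-fold higher number from compound 2 to compound 3 (0.18 log units; within the scatter) in this assay. Compound 3 is therefore estimated at 3.5 nM, within 1 nM to 12 nM.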

Compound 3, inhibition constant: 3.2 nM
For compound 3 the middle estimate is 1.1-fold (0.04 log units) above the measured one, within the range that was stated.
By their numbers in this assay, from the lowest: compound 1; then compounds 2 and 3 (each within the scatter of the next).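

The exchange of 4-methoxyphenyl for furan-2-yl on a saturated chain carbon bound to a sulfur takes the group from eight heavy atoms to five and swaps a six-membered aromatic ring for a five-membered one, yet the step, a 1.4-fold higher number from compound 2 to compound 3 (0.14 log units; within the scatter), stays within the scatter in this assay. The step of a 4.6-fold higher number from compound 1 to compound 3 (0.66 log units; beyond the scatter) is modest but beyond the scatter, so compound 1, with its cyclohexyloxy group, stays apart from both sulfanyl compounds, which cannot be told apart from each other. Nothing available explains these numbers.

The compounds shown leave open whether a cyclohexyl group, an amine or a carboxylic acid on that chain carbon would fit the same pattern. They also leave open what an oxygen link in place of the sulfur would do with the (furan-2-yl)methyl group kept.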